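Removing a Chloro Group on a Shared Core: Two Parallel Steps

A few compounds are considered here, and "the series" means these few. Any claim that something is new, unique, unknown or untested is made for them only; others in the source may bear on it.

Compound 1 `CCN(CC)CN1C(=O)/C(=N\c2nc3ccc(C)cc3s2)c2ccccc21` gives 32700 nM in a functional assay on MDA-MB-231 cells (Homo sapiens) for cytotoxicity, read by sulforhodamine B assay, with a stated time of 48 h; a lower number here means a stronger inhibitor of growth, a higher number a weaker inhibitor of growth.
Compound 2 `Cc1ccc2nc(/N=C3\C(=O)N(CN(c4ccccc4)c4ccccc4)c4cccc(Cl)c43)sc2c1` gives 54000 nM in this assay.
Compound 3 `CCN(CC)CN1C(=O)/C(=N\c2nc3ccc(C)cc3s2)c2c(Cl)cccc21` gives 20400 nM in this assay.

Compound 3 and compound 1 differ in one place, (hydrogen in place of chloro on an aromatic carbon), and this change made a step of a 1.6-fold higher number from compound 3 to compound 1 (0.20 log units; within the scatter). Compound 2 differs from compound 3 in more than one place, and the difference between the two cores is not broken down here. Compound 4 `Cc1ccc2nc(/N=C3\C(=O)N(CN(c4ccccc4)c4ccccc4)c4ccccc43)sc2c1` has not yet been measured; it differs from compound 2 by hydrogen in place of chloro on an aromatic carbon, the same change that turns compound 3 into compound 1, at the same place. For compound 4 a step of a 1.4-fold higher number from compound 2 to compound 4 (0.14 log units; within the scatter) is expected, resting on the earlier step of a 1.6-fold higher number from compound 3 to compound 1 (0.20 log units; within the scatter). Compound 4 is estimated at 75000 nM, likely between 30000 nM and 180000 nM.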

Compound 4, concentration for 50% growth inhibition: 34100 nM
The estimate for compound 4 lay 2.2-fold (0.34 log units) above the measured number; low and high end bracket the measured number.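

In this assay, putting hydrogen in place of chloro on the core of compound 2 gives a 1.6-fold lower number from compound 2 to compound 4 (0.20 log units; within the scatter), and the two parallel steps compare as follows: the same change on two cores in this assay, a 1.6-fold higher number (0.20 log units; within the scatter) from compound 3 to compound 1 and a 1.6-fold lower number (0.20 log units; within the scatter) from compound 2 to compound 4, 2.5-fold (0.40 log units) apart, within the scatter of two such steps. On these two cores, then, the change stays within the scatter each time, and the opposite directions of the steps do not count as a real disagreement between the cores. This does not show that chloro has no effect at all, and two pairs say nothing about how the change would behave on a third core.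

The compounds shown leave open whether a different group on that aromatic carbon, such as methoxy, nitrile or an amine, would shift the number beyond the scatter.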